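Nitro on the benzoyl ring of the shared core

The source may report more compounds than this note shows. Statements on the series, on what has been measured and on what is new or still open speak of the compounds shown alone.

Within the data shown here, compound 3 `O=C(COc1ccc2c(=O)ccoc2c1)Nc1cccc(NC(=O)c2ccccc2)c1` gives the lowest number of the three measured so far: in an assay on isolated protein for inhibition of Rho-associated protein kinase 2 (Homo sapiens), read by scintillation counting, radiometric assay and 33P incorporation, with a stated time of 40 min, in the presence of a further agent that is not named here (a lower number here means a stronger inhibitor, a higher number a weaker inhibitor), compound 3 gives 16 nM. Compound 2 `CN(C)c1ccc(C(=O)Nc2cccc(NC(=O)COc3ccc4c(c3)OCCC4=O)c2)cc1` gives 85 nM and compound 1 `COc1ccc(OCC(=O)Nc2cccc(NC(=O)c3ccc(N(C)C)cc3)c2)cc1F` gives 652 nM. Among the measured compounds shown here, the one step between neighbours, a 7.7-fold lower number from compound 1 to compound 2 (0.88 log units; beyond the scatter), concerns the group on an oxygen on a saturated carbon, a different place in the shared core. Compound 4 `O=C(COc1ccc2c(=O)ccoc2c1)Nc1cccc(NC(=O)c2cccc([N+](=O)[O-])c2)c1` differs from compound 3 by nitro in place of hydrogen on an aromatic carbon. For the measured compounds named here, no measured step touches that ring; the only step at hand, a 7.7-fold lower number from compound 1 to compound 2 (0.88 log units; beyond the scatter), lies elsewhere and gives no direction. The expected step is therefore a 1.3-fold higher number from compound 3 to compound 4 (0.10 log units; within the scatter), within the scatter. Compound 4 is estimated at 20 nM, with a range from 6 nM to 60 nM.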

Compound 4, half-maximal inhibitory concentration: 41 nM
Beside the measured number, compound 4's estimate is 2.1-fold (0.31 log units) below it; low and high end bracket the measured number.
By their numbers in this assay, from the lowest: compound 3; then compound 4; then compound 2; then compound 1.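

First step on this ring: nitro in place of hydrogen on an aromatic carbon, meta to a large group, gives a 2.6-fold higher number from compound 3 to compound 4 (0.41 log units; beyond the scatter) and so moves the number upward, which the earlier compounds, whose only step lay at another place in the shared core, could not show. The position is therefore sensitive to substitution, though the change is modest and rests on this single pair. Nothing at hand accounts for the direction of this step.

Open, as far as these compounds go, is whether an amine or a carboxylic acid in place of nitro on the same carbon would also raise the number. Equally open, from the compounds shown here alone, is how nitro would behave at another place on that ring.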